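Furan acrylamides: phenyl for methyl on the furan

The source may hold more compounds than are shown below. What is called first, only, known or untested is meant among the compounds shown, and "the series" means these compounds.

Among the measured compounds shown here, in a functional assay on SJ-G2 cells (Homo sapiens) for inhibition, read by MTT assay, with a stated time of 72 h (on this read-out lower numbers stand for stronger inhibition of growth and higher numbers for weaker inhibition of growth), compound 2 `COc1ccc(CNC(=O)/C(C#N)=C/c2ccc(C)o2)cc1` gives 75000 nM, the only numerical value in the set. Compound 1 `N#C/C(=C\c1ccco1)C(=O)NCc1ccc(Cl)c(Cl)c1` returns > 50000 nM, which is a limit of the assay and not a number; compound 1 therefore stands at the limit of > 50000 nM in this assay, at which 1 of the 2 values shown sits. Compound 3 `COc1ccc(CNC(=O)/C(C#N)=C/c2ccc(-c3ccccc3)o2)cc1` differs from compound 2 by phenyl in place of methyl on an aromatic carbon, next to the ring oxygen. For the measured compounds named here, no measured pair in the set covers this change, so no direction beyond the scatter is expected; the step from compound 2 to compound 3 is estimated as a 1.3-fold lower number from compound 2 to compound 3 (0.10 log units; within the scatter) in this assay. Compound 3 is accordingly expected near 60000 nM, within 20000 nM to 150000 nM, with a fair chance that only a limit is reported.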

Compound 3, concentration for 50% growth inhibition: > 100000 nM
Compound 3: a limit, no number; the forecaster's own chance of this, stated with the estimate: 40%; at least 1.6-fold (0.22 log units) between middle value and limit.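

Among the compounds shown here, this is the first reading at the furan position: phenyl in place of methyl on the aromatic carbon next to the ring oxygen gives an at least 1.3-fold higher number from compound 2 to compound 3 (0.12 log units; that floor lies within the scatter). The larger aromatic group therefore shows no stronger inhibition of growth in this assay. The value for compound 3 is a limit of the assay, not a number: the limit of > 100000 nM in this assay, at which 1 of the 3 values shown sits.

Going by these compounds, the true size of this step stays open. Also open, on these data alone, is whether an aminomethyl group or a carboxylic acid on this carbon would give a measurable value in this assay.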